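The compounds below may be only part of what the source reports. "The series", "measured", "known", "first", "only" and "open" are said of these compounds alone.

Measured compounds:
- compound 1, `Nc1scc(CN2CCN(c3cccnc3)CC2)c1C(=O)c1ccc(Cl)cc1`, in a functional assay on CHO cells with adenosine receptor A1 (Homo sapiens) as the target, read by cAMP accumulation and immunoassay, with a stated time of 6 min, tested at 0.1 uM (on this read-out lower numbers stand for a stronger effect and higher numbers for a weaker effect at the one concentration tested), gives 3.4%
- compound 2, `Nc1scc(CN2CCN(c3ccc(F)c(F)c3)CC2)c1C(=O)c1ccc(Cl)cc1`, in this assay gives -34%

Among the measured compounds shown here, of the two numbers measured so far, compound 2 stands lowest, and its nearest neighbour is compound 1, whose number is higher by an amount beyond the usual scatter; the single measured step is a number 37.4 percentage points lower from compound 1 to compound 2 (beyond the scatter).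

The unmeasured compound 3, `Nc1scc(CN2CCN(c3cccc(F)c3F)CC2)c1C(=O)c1ccc(Cl)cc1`, differs from compound 2 as follows: 2,3-difluorophenyl in place of 3,4-difluorophenyl on an amine nitrogen in a ring. The two difluorophenyl groups are made of the same atoms, joined differently, and both sit on the same ring nitrogen of the shared core.

For the measured compounds named here, no measured step matches this change: the only step in hand swaps a pyridin-3-yl for a 3,4-difluorophenyl, which is a different kind of change, and it was large. Moving the two fluorines within the ring has no precedent here, so there is no ground to expect a large move in either direction, and the estimate stays close to compound 2 with a wide range. Compound 3 is expected to give about -22%, somewhere between -55% and 10%, which means an expected step of a number 12 percentage points higher from compound 2 to compound 3 (beyond the scatter), within the scatter.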

Compound 3, a percentage reported as activity, at one concentration (the size of the read-out at that concentration, not a potency): -5.2%
Compound 3: middle estimate off by 16.8 percentage points, on the low side; low and high end bracket the measured number.
By their numbers in this assay, from the lowest: compound 2; then compounds 3 and 1 (each within the scatter of the next).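

Moving the two fluorines on the phenyl group, with the same atoms on the same ring nitrogen, gives a number 28.8 percentage points higher from compound 2 to compound 3 (beyond the scatter) in this assay and so shows that the arrangement of the fluorines alone can change this read-out, something the earlier pair could not show because it changed the ring itself. The replacement of pyridin-3-yl by 2,3-difluorophenyl gives a number 8.6 percentage points lower from compound 1 to compound 3 (within the scatter) and leaves compound 1 and compound 3 indistinguishable here, so a difluorophenyl group at this position does not by itself bring the number down to that of compound 2. No measurement here explains why the two fluorine arrangements differ.

The compounds shown leave open whether a plain phenyl, a chlorophenyl or a methoxyphenyl group on this ring nitrogen would fall closer to compound 2 or to compound 3. With only one concentration tested, they also leave open how the potencies of these compounds compare, as a single read-out reports the size of the effect at that concentration and not a potency.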